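Swapping an iodophenyl for a furan ring

The compounds below may be only part of what the source reports. "The series", "measured", "known", "first", "only" and "open" are said of these compounds alone.

Three compounds share one core and differ only in the group attached to the carbonyl carbon of the amide. Compound 1 `COCC(=O)Nc1c(C(O)(C(F)(F)F)C(F)(F)F)ccc2ccccc12` gives 213 nM in an assay on LtK cells with ATP-sensitive inward rectifier potassium channel 11 (Homo sapiens) as the target; on this read-out higher numbers stand for an effect only at larger amounts of compound and lower numbers for an effect already at smaller amounts. Compound 2 `O=C(Nc1c(C(O)(C(F)(F)F)C(F)(F)F)ccc2ccccc12)c1ccc(F)cc1` gives 70 nM, and compound 3 `O=C(Nc1c(C(O)(C(F)(F)F)C(F)(F)F)ccc2ccccc12)c1ccc(I)cc1` gives 154 nM. Compound 3 thus holds the second-highest number of the three: its gap to compound 1 lies within the scatter, while the step of a 2.2-fold higher number from compound 2 to compound 3 (0.34 log units; beyond the scatter) lies beyond it. Compound 4 `O=C(Nc1c(C(O)(C(F)(F)F)C(F)(F)F)ccc2ccccc12)c1ccco1` carries furan-2-yl in place of 4-iodophenyl on a carbonyl carbon. Going by the values given here, the steps of a 3.0-fold lower number from compound 1 to compound 2 (0.48 log units; beyond the scatter) and a 1.4-fold lower number from compound 1 to compound 3 (0.14 log units; within the scatter) show that changing this group moves the number only modestly, and no measured step exchanges a six-membered for a five-membered ring. A change within or barely beyond the scatter is therefore expected, a 1.0-fold higher number from compound 3 to compound 4 (0.02 log units; within the scatter). Compound 4 is estimated at 160 nM, within 60 nM to 450 nM.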

Compound 4, half-maximal effective concentration: 9 nM
The estimate for compound 4 lay 18-fold (1.25 log units) above the measured number; measured number below the stated range.
By their numbers in this assay, from the lowest: compound 4; then compound 2; then compounds 3 and 1 (each within the scatter of the next).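

Swapping the six-membered aromatic ring or the methoxymethyl group for furan-2-yl on this carbonyl carbon gives a 17-fold lower number from compound 3 to compound 4 (1.23 log units; beyond the scatter), a 7.8-fold lower number from compound 2 to compound 4 (0.89 log units; beyond the scatter) and a 24-fold lower number from compound 1 to compound 4 (1.37 log units; beyond the scatter). Each step is larger than any among the first three compounds, so this position can move the number much further than they suggested, and compound 4 has the lowest number of the four. No measurement here explains this drop. As far as these compounds go, it remains open whether the ring oxygen or the five-membered ring matters more. A thiophen-2-yl group, with sulfur in place of the ring oxygen, would help separate the two.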